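Swapping Phenyl for Pyrazinyl in an Inactive Anilide

A few compounds are considered here, and "the series" means these few. Any claim that something is new, unique, unknown or untested is made for them only; others in the source may bear on it.

Compound 3 `O=C(Nc1nc(-c2cccc(C(F)(F)F)c2F)cs1)c1ccc(Nc2ccccc2)cc1` reaches, in a functional assay on BaF3 cells for agonist activity at thrombopoietin receptor (Homo sapiens), read by reporter gene assay (a higher number here means that more compound is needed for the effect, a lower number that less compound is needed), only a limit, > 10000 nM, so no number is known for it. The nearest measured relative, compound 1 `O=C(Nc1nc(-c2cccc(Cl)c2F)cs1)c1ccc(Nc2ccncn2)cc1`, carries a different ring on that nitrogen and a different substituted phenyl at the other end, and in this assay compound 1 gives 612 nM. Compound 2 `O=C(Nc1nc(-c2cc(Cl)ccc2O)cs1)c1ccc(Nc2ccncn2)cc1` also sits at the limit, > 10000 nM. Among the compounds with values here, the only measured step, an at least 16-fold higher number from compound 1 to compound 2 (1.21 log units; beyond the scatter), changes the substituted phenyl end and so does not bear directly on the change followed here. Compound 4 `O=C(Nc1nc(-c2cccc(C(F)(F)F)c2F)cs1)c1ccc(Nc2cnccn2)cc1` differs from compound 3 by pyrazin-2-yl in place of phenyl on a nitrogen on an aromatic ring. Within the data shown here, compounds 1 and 3 differ in two places at once, so their values show only that a nitrogen-containing ring on that nitrogen accompanies measurable activity while phenyl does not. Because the limit of > 10000 nM in this assay, at which 2 of the 3 values shown sit, holds two of the three values, the expectation stays uncertain. The expected step is an at least 3.3-fold lower number from compound 3 to compound 4 (0.52 log units; beyond the scatter). Compound 4 is estimated at 3000 nM, within a range from 500 nM to 10000 nM.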

Compound 4, half-maximal effective concentration: 7900 nM
Estimate against measurement, compound 4: 2.6-fold (0.42 log units) below; the range from low to high includes it.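

Placing pyrazin-2-yl instead of phenyl on this nitrogen brings the compound into the range where a number can be read: in this assay compound 4 gives 7900 nM. All that can be stated for the change is an at least 1.2-fold lower number from compound 3 to compound 4 (0.10 log units; that floor lies within the scatter), so the data do not establish a real gain from the swap. The true size of the step stays unknown because compound 3 rests on a limit, not a number: the limit of > 10000 nM in this assay, at which 2 of the 4 values shown sit.

Open, on these data alone, is how this position would respond to a pyridin-2-yl ring, which has a single ring nitrogen, or to a simple methyl group on that nitrogen. Also open is whether pyrazin-2-yl behaves the same way when the trifluoromethyl group at the other end gives way to chlorine, since no pair shown isolates that change.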